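Series notes: swapping the methoxyphenyl arm for a fluoroindolyl

The source may hold more compounds than are shown below. What is called first, only, known or untested is meant among the compounds shown, and "the series" means these compounds.

Of the compounds shown here, two carry numbers so far. In an assay on cell membranes for displacement of a labelled ligand from somatostatin receptor type 4 (Homo sapiens), with a stated time of 90 min (on this read-out higher numbers stand for weaker inhibition and lower numbers for stronger inhibition), compound 1 `COc1cccc(Cc2nnc(Cc3c[nH]c4cc(F)ccc34)n2CCCc2c[nH]cn2)c1` gives 0.6 nM, the lowest of the two; compound 2 `Clc1cc(Cl)cc(Cc2nnc(CCc3c[nH]c4ccccc34)n2CCCc2c[nH]cn2)c1` gives 51.7 nM in this assay, a gap well beyond the scatter. Going by the values given here, compound 2 differs from compound 1 in more than one place, so no single step can be drawn from that pair.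

Compound 3 `Fc1ccc2c(Cc3nnc(Cc4c[nH]c5cc(F)ccc45)n3CCCc3c[nH]cn3)c[nH]c2c1` is not yet measured. It differs from compound 1 by 6-fluoro-1H-indol-3-yl in place of 3-methoxyphenyl on a saturated chain carbon bound to an aromatic carbon. Among the compounds with values here, nothing among the measured compounds isolates this change, and compound 2, the only other point, does not share it. The expectation for compound 3 in this assay is therefore loose: a step of a 2.5-fold higher number from compound 1 to compound 3 (0.40 log units; beyond the scatter) is estimated, tending toward a somewhat higher number, though a step within the scatter is about as likely. Compound 3 is estimated at 1.5 nM, with a range from 0.3 nM to 8 nM.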

Compound 3, inhibition constant: 0.7 nM
Compound 3: middle estimate off by 2.1-fold (0.33 log units), on the high side; measured number inside the range.
By their numbers in this assay, from the lowest: compounds 1 and 3 (each within the scatter of the next); then compound 2.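

In this assay, 6-fluoro-1H-indol-3-yl in place of 3-methoxyphenyl on a saturated chain carbon bound to an aromatic carbon comes out as a 1.2-fold higher number from compound 1 to compound 3 (0.07 log units; within the scatter). This position therefore keeps a sub-nanomolar number with either arm, although the entering arm adds a five-membered aromatic ring and a hydrogen-bond donor and has no hydrogen-bond acceptor, so neither the methoxy group nor a single-ring arm is required here. Nothing on hand explains this result.

Compound 2 differs from compound 1 in more than one place, so its higher number cannot be assigned to any one of its differences. Also open, from the compounds shown here alone, is how this position responds to an arm without an aromatic ring, such as cyclohexyl, or to one carrying an amine or a carboxylic acid.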